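Swapping ethyl for fluoro on a xanthine binder

The source may hold more compounds than are shown below. What is called first, only, known or untested is meant among the compounds shown, and "the series" means these compounds.

Going by the values given here, compound 1, with the structure `CCc1ccc(-c2nc3c(=O)n(C)c(=O)n(C)c3[nH]2)cc1`, is one of two compounds measured in an assay for binding affinity to adenosine receptor A1 (Bos taurus); on this read-out higher numbers stand for weaker inhibition and lower numbers for stronger inhibition. In this assay compound 1 gives 0.8 nM. The other measured compound is compound 2, with the structure `CCCn1c(=O)c2nc(-c3ccc(Cl)cc3N)[nH]c2n(CCC)c1=O`, which in this assay gives 0.05 nM. Of the two numbers, that of compound 1 is the higher, and the gap to compound 2 lies beyond the usual scatter; the two structures differ in several places at once, so nothing about any single change can be read from that gap.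

Compound 3, with the structure `Cn1c(=O)c2nc(-c3ccc(F)cc3)[nH]c2n(C)c1=O`, has not yet been measured. It differs from compound 1 in one place: fluoro in place of ethyl on an aromatic carbon. Among the compounds with values here, no measured pair in this set isolates this change, so the expectation rests on the change alone. The step from compound 1 to compound 3 is expected to be a 6.3-fold higher number from compound 1 to compound 3 (0.80 log units; beyond the scatter), a modest loss of affinity, beyond the scatter but not large. Compound 3 is therefore estimated to give 5 nM in this assay, with a likely range from 1.5 nM to 20 nM.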

Compound 3, half-maximal inhibitory concentration: 3.5 nM
The estimate for compound 3 lay 1.4-fold (0.15 log units) above the measured number; the measured number falls inside the stated range.
By their numbers in this assay, from the lowest: compound 2; then compound 1; then compound 3.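

Going by these compounds alone, this is the only pair in the set that differs in one place, so a change in the number can be tied to a single swap: in this assay the result is a 4.4-fold higher number from compound 1 to compound 3 (0.64 log units; beyond the scatter) when fluoro replaces ethyl on the aromatic carbon para to a large group. The step is modest but beyond the usual scatter, which shows that the number responds to what sits at this carbon, even though neither group counts any hydrogen-bond donor or acceptor. Nothing available here explains why this swap raises the number.

With only ethyl and fluoro compared at this carbon, a single step cannot show which difference between the two groups matters, or whether other groups, such as a methoxy group, a carboxylic acid or a longer chain like butyl, would give a lower or a higher number. Compound 2 differs from the other two compounds in several places, so it also leaves open whether the same swap would give a step of similar size on the core of compound 2.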